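Piperidinylmethyl extension of the amide chain in a quinazoline series

The compounds below may be only part of what the source reports. "The series", "measured", "known", "first", "only" and "open" are said of these compounds alone.

Three measured compounds define the series. Compound 1 `CC(C)=CC(=O)Nc1cc2c(N3CCc4ccccc43)ncnc2cc1O[C@@H]1CCOC1` gives 4620 nM in a functional assay on PC-3 cells (Homo sapiens) for antiproliferative activity, read by MTT assay, with a stated time of 72 h; a higher number here means a weaker inhibitor, a lower number a stronger inhibitor. Compound 2 `C/C=C/C(=O)Nc1cc2c(N3CCCc4ccccc43)ncnc2cc1OC` gives 7520 nM in this assay, and compound 3 `C/C=C/C(=O)Nc1cc2c(N3CCCc4ccccc43)ncnc2cc1O[C@@H]1CCOC1` gives 9350 nM in this assay. On these numbers compound 2 sits within the scatter of both neighbours: its nearest is compound 3, its furthest compound 1, and neither gap exceeds the usual spread of repeated runs.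

Within the data shown here, only one single-point step is available: a 1.2-fold higher number from compound 2 to compound 3 (0.09 log units; within the scatter). Compound 1 and compound 2 differ in more than one place, so their values are simply noted side by side without a step.

Compound 4 `COc1cc2ncnc(N3CCCc4ccccc43)c2cc1NC(=O)/C=C/CN1CCCCC1` arises from compound 2 by piperidin-1-yl in place of hydrogen on a saturated chain carbon bound to a double-bonded chain carbon. Among the measured compounds shown here, no measured step touches this part of the molecule; the one step on record alters the ether substituent on the ring and stays within the scatter, so it gives no lean in either direction for the amide chain. The expectation in this assay is therefore a change no larger than the scatter, with a slight lean toward a lower number in view of the wide uncertainty. The step of a 1.5-fold lower number from compound 2 to compound 4 (0.18 log units; within the scatter) is the estimate that follows. Compound 4 is expected at 5000 nM, ranging from 1500 nM to 16000 nM.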

Compound 4, half-maximal inhibitory concentration: 5780 nM
For compound 4 the middle estimate is 1.2-fold (0.06 log units) below the measured one; low and high end bracket the measured number.
By their numbers in this assay, from the lowest: compounds 1, 4, 2 and 3 (each within the scatter of the next, the first and the last beyond it).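

Piperidin-1-yl in place of hydrogen on a saturated chain carbon bound to a double-bonded chain carbon gives a 1.3-fold lower number from compound 2 to compound 4 (0.11 log units; within the scatter) in this assay, the first reading at the amide chain rather than at the ether substituent on the ring. This position therefore takes a group of 6 heavy atoms, with a six-membered non-aromatic ring and 1 hydrogen-bond acceptor, with no departure from the scatter, so methyl and (piperidin-1-yl)methyl at the end of the chain cannot be told apart on this read-out. No supporting measurement bears on why the number holds level, and the step alone does not settle it.

Open, as far as these compounds go, is whether another amine on the same carbon, such as dimethylamino or morpholin-4-yl, a carboxylic acid there, or a longer chain carrying the piperidin-1-yl, would give a step beyond the scatter in this assay. Also open, from the compounds shown here alone, is whether the (piperidin-1-yl)methyl end gives the same reading when the methyl on the ring oxygen is replaced by the oxolan-3-yl of compound 3.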